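The compounds below may be only part of what the source reports. "The series", "measured", "known", "first", "only" and "open" are said of these compounds alone.

Compound 1 `COc1cccc(CNc2ncnc3c2ncn3[C@@H]2O[C@H](CO)[C@@H](O)[C@H]2O)c1OC` in a functional assay on MCF cells (Homo sapiens) for antiproliferative activity, with a stated time of 72 h (a lower number here means a stronger inhibitor, a higher number a weaker inhibitor), gives > 166000 nM, which is a limit of the assay and not a number. Compound 2 `OC[C@H]1O[C@@H](n2cnc3c(NCc4ccc(F)cc4F)ncnc32)[C@H](O)[C@@H]1O` in this assay gives > 166000 nM, again only a limit. Compound 3 `OC[C@H]1O[C@@H](n2cnc3c(NCc4ccc(C(F)(F)F)cc4)ncnc32)[C@H](O)[C@@H]1O` remains to be measured in this assay.

Compound 2 stands at a limit, and every value shown so far is a limit as well (the limit of > 166000 nM in this assay, at which 2 of the 2 values shown sit). The change from compound 2 to compound 3 is 4-(trifluoromethyl)phenyl in place of 2,4-difluorophenyl on a saturated chain carbon bound to a nitrogen on an aromatic ring. Within the data shown here, the only measured step, a step that the two limits leave unreadable from compound 1 to compound 2, runs between two limits and its size cannot be read, so no measured step shows how a swap of this kind at this position moves the read-out. With nothing readable to build on, no shift beyond the scatter is expected, and compound 3 is expected to remain at the limit a step that the limit leaves unreadable from compound 2 to compound 3. The estimate for compound 3 is 200000 nM, with a range from 50000 nM to 1000000 nM.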

Compound 3, half-maximal inhibitory concentration: > 166000 nM
Compound 3 ended at the assay's limit; the forecaster's own chance of this, stated with the estimate: 85%; the middle value is on the limit's open side.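

The steps among compound 1, compound 2 and compound 3 cannot be read, because all three compounds sit at the same limit of the assay and give no number: the limit of > 166000 nM in this assay, at which 3 of the 3 values shown sit.

The compounds shown leave open whether any group on a saturated chain carbon bound to a nitrogen on an aromatic ring can give a measurable value in this assay.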